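The source may hold more compounds than are shown below. What is called first, only, known or untested is meant among the compounds shown, and "the series" means these compounds.

Working notes on the series in an ADME assay (liver, Mus musculus) for metabolic stability, read by LC-MS, using microsomes, tested at 1 uM; a higher number here means that the compound lasts longer, a lower number that the compound disappears faster.

Compound 1 `CCN(CC)CCN/C(=N\c1ccnc2cc(Cl)ccc12)C(C)C` gives 0.2 h in this assay. Compound 2 `C/C(=N/c1ccnc2cc(Cl)ccc12)NC1CCN(C)CC1` gives only a limit in this assay, > 1 h. Compound 3 `CCN(CC)CCCCN/C(C)=N\c1ccnc2cc(Cl)ccc12` likewise gives only a limit in this assay, > 1 h, so its place among the numbers is not fixed beyond that. Two of the three values reported so far sit at the limit of > 1 h in this assay, at which 2 of the 3 values shown sit; only compound 1 returns a number inside the range of this assay.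

Compound 4 `CCN(CC)CCN/C(C)=N\c1ccnc2cc(Cl)ccc12` has not been measured in this assay. The change from compound 3 is diethylamino in place of 2-(diethylamino)ethyl on a saturated chain carbon, two bonds along the chain from an amine nitrogen. Among the measured compounds shown here, no measured pair isolates that change, so its effect here rests on expectation alone. Compound 3 sits at a limit. Compound 1, which shares the shorter chain, gives 0.2 h, which leaves room for a loss beyond the usual scatter. The step is expected to be an at least 1.4-fold lower number from compound 3 to compound 4 (0.15 log units; that floor lies within the scatter), downward. Compound 4 is estimated at 0.7 h, within a range from 0.25 h to 1.5 h, with a fair chance that this assay returns only a limit again.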

Compound 4, half-life: 0.3 h
For compound 4 the middle estimate is 2.3-fold (0.37 log units) above the measured one, and the stated range covers the measured number.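

In this assay, diethylamino in place of 2-(diethylamino)ethyl on a saturated chain carbon, two bonds along the chain from an amine nitrogen, now has a readable size: an at least 3.3-fold lower number from compound 3 to compound 4 (0.52 log units; beyond the scatter). On an amine nitrogen, 2-(diethylamino)ethyl in place of 1-methylpiperidin-4-yl gives an at least 3.3-fold lower number from compound 2 to compound 4 (0.52 log units; beyond the scatter). With the shorter chain kept, methyl in place of isopropyl on a carbon with a double bond to nitrogen gives a 1.5-fold higher number from compound 1 to compound 4 (0.18 log units; within the scatter), so this change stays within the scatter while the other two go beyond it.

The full size of the first two steps stays open because compound 2 and compound 3 each give only a limit: the limit of > 1 h in this assay, at which 2 of the 4 values shown sit.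

Also open, from the compounds shown here alone, is how a primary amine in place of diethylamino would behave in this assay.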